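Benzyl for Phenyl on the Aryl Ether Oxygen

The compounds below may be only part of what the source reports. "The series", "measured", "known", "first", "only" and "open" are said of these compounds alone.

Compound 2, `Cc1[nH]c(=O)n(C2CCCCC2)c1-c1ccc(Oc2ccccc2)cc1`, holds the lowest of the two numbers recorded in a functional assay on the whole organism with Rattus norvegicus as the target (a lower number here means that less compound is needed, a higher number that more compound is needed for the effect), giving 0.1 mg/kg. Its nearest neighbour, compound 1, `CCCCCCCCOc1ccc(-c2c(C)[nH]c(=O)n2C2CCCCC2)cc1`, gives 30 mg/kg in this assay. Among the measured compounds shown here, the one step that joins them, a 300-fold lower number from compound 1 to compound 2 (2.48 log units; beyond the scatter), sits at the same oxygen on the aromatic ring where the next change is made, and it shows that this position can move the number a long way. Compound 3, `Cc1[nH]c(=O)n(C2CCCCC2)c1-c1ccc(OCc2ccccc2)cc1`, differs from compound 2 by benzyl in place of phenyl on an oxygen on an aromatic ring. For the measured compounds named here, no measured pair tells how a benzyl compares with a phenyl here, so the direction is open, but the size of the earlier step argues for caution rather than for assuming no change. Compound 3 is therefore expected to give 0.3 mg/kg, within 0.03 mg/kg to 3 mg/kg, a step of a 3.0-fold higher number from compound 2 to compound 3 (0.48 log units; beyond the scatter).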

Compound 3, minimum effective dose: 0.1 mg/kg
Estimate against measurement, compound 3: 3.0-fold (0.48 log units) above; the range from low to high includes it.
By their numbers in this assay, from the lowest: compounds 2 and 3 (each within the scatter of the next); then compound 1.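

In (this assay), benzyl in place of phenyl on an oxygen on an aromatic ring gives (no change at the digits printed from compound 2 to compound 3 (within the scatter)), so at this position the low number seen with phenyl survives this change. Compound 3 also gives a second comparison with the octyl compound, (a 300-fold lower number from compound 1 to compound 3 (2.48 log units; beyond the scatter)), and this step is the same size as (a 300-fold lower number from compound 1 to compound 2 (2.48 log units; beyond the scatter)), so both compounds with an aromatic ring in the group on this oxygen stand far from compound 1. No supporting measurement accounts for these results.

From the compounds shown here alone, whether phenethyl, a shorter chain such as butyl, or a benzyl carrying an amine would keep the number this low on the same oxygen stays open. The compounds shown also leave open how a carboxylic acid at this position would compare with phenyl or benzyl.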